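From 4-methylphenyl to 2-nitrophenyl on the sulfonyl sulfur

The compounds below may be only part of what the source reports. "The series", "measured", "known", "first", "only" and "open" are said of these compounds alone.

Measured in a functional assay on NCI-H460 cells (Homo sapiens) for cytotoxicity, read by MTT assay, with a stated time of 3 days; a lower number here means a stronger inhibitor, a higher number a weaker inhibitor:
compound 1 `CN1CCN(c2nc(SCc3nc4ccccc4[nH]3)nc(-c3ccccc3)c2C#N)CC1`: 2.84 nM
compound 2 `N#Cc1c(-c2ccccc2)nc(SCc2nc3ccccc3[nH]2)nc1N1CCN(S(=O)(=O)c2ccccc2)CC1`: 4.6 nM
compound 3 `Cc1ccc(S(=O)(=O)N2CCN(c3nc(SCc4nc5ccccc5[nH]4)nc(-c4ccccc4)c3C#N)CC2)cc1`: 22.7 nM

Compound 3 has the highest number of the three, and an 8.0-fold higher number from compound 1 to compound 3 (0.90 log units; beyond the scatter) is beyond the scatter. Compound 4 `N#Cc1c(-c2ccccc2)nc(SCc2nc3ccccc3[nH]2)nc1N1CCN(S(=O)(=O)c2ccccc2[N+](=O)[O-])CC1` keeps the shared core and differs at one place, with 2-nitrophenyl in place of 4-methylphenyl on a sulfonyl sulfur.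

The nearest evidence is a 4.9-fold higher number from compound 2 to compound 3 (0.69 log units; beyond the scatter), a modest step that came with a methyl on an aromatic carbon. Compound 4 also lacks that methyl, which points towards a lower number. The step of a 1.6-fold higher number from compound 1 to compound 2 (0.21 log units; within the scatter) adds that the sulfonyl compound without the methyl stays within the scatter of the methyl-bearing amine. Among the compounds with values here, no measured compound carries a 2-nitrophenyl group, so the effect of that group remains open and the expectation is loose. A modest move to a lower number is expected in this assay, with the estimated step being a 2.3-fold lower number from compound 3 to compound 4 (0.36 log units; beyond the scatter). For compound 4 the estimated value is 10 nM, with an expected range of 3 nM to 35 nM.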

Compound 4, half-maximal inhibitory concentration: 3.7 nM
Beside the measured number, compound 4's estimate is 2.7-fold (0.43 log units) above it, within the range that was stated.
By their numbers in this assay, from the lowest: compounds 1, 4 and 2 (each within the scatter of the next); then compound 3.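

In this assay the sulfonyl sulfur tolerates 2-nitrophenyl in place of 4-methylphenyl, with a 6.1-fold lower number from compound 3 to compound 4 (0.79 log units; beyond the scatter) for this change. Nitro in place of hydrogen on the aromatic carbon gives a 1.2-fold lower number from compound 2 to compound 4 (0.09 log units; within the scatter) and (2-nitrophenyl)sulfonyl in place of methyl on the ring amine nitrogen gives a 1.3-fold higher number from compound 1 to compound 4 (0.11 log units; within the scatter) so compound 1, compound 2 and compound 4 all read alike, and compound 3 alone stands apart; a group on the phenyl ring therefore does not by itself bring the higher number, since the methyl of compound 3 does and the nitro of compound 4 does not. No measurement offered here accounts for that difference.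

On these data alone, it remains open whether the result belongs to the nitro group or to where it sits, which a 4-nitrophenyl or a 2-methylphenyl group on the sulfonyl sulfur would help to separate. How an amine or a carboxylic acid on that phenyl ring would read in this assay is also unknown.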